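This account rests on a few compounds, and the source may have more. Where it says the series, first, only, none or still open, it means among the compounds named here.

In a functional assay, read by spectrophotometry, with a stated time of 6 min (a lower number here means a stronger inhibitor, a higher number a weaker inhibitor), compound 1 (`CCCCCCCCCCOc1cc(OC)c(Br)cc1C(C)=O`) gives 34700000 nM and compound 2 (`CCCCCCCCCCCCOc1cc(OC)c(Br)cc1C(C)=O`) gives 32700000 nM while compound 3 (`CCCCCCCCCCCCCCCCOc1cc(OC)c(Br)cc1C(C)=O`) gives 4600000 nM as the lowest number of the three. Lengthening the chain gives a 1.1-fold lower number from compound 1 to compound 2 (0.03 log units; within the scatter) and then a 7.1-fold lower number from compound 2 to compound 3 (0.85 log units; beyond the scatter) as the only measured steps. Compound 4 (`CCCCCCCCCCCCCCCCOc1cc(OC)ccc1C(C)=O`) keeps the chain of compound 3 but carries hydrogen in place of bromo on an aromatic carbon. Within the data shown here, no measured compound lacks the bromo, so these chain steps offer only a rough guide to size and none to direction. The expected size is no larger than the bigger chain step, and the estimated step is a 1.1-fold higher number from compound 3 to compound 4 (0.04 log units; within the scatter) with no firm direction. The estimate for compound 4 is 5000000 nM (expected range 1300000 nM to 19000000 nM).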

Compound 4, half-maximal inhibitory concentration: 36300000 nM
Estimate against measurement, compound 4: 7.3-fold (0.86 log units) below; the measured number lies above the stated range.
By their numbers in this assay, from the lowest: compound 3; then compounds 2, 1 and 4 (each within the scatter of the next).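

Hydrogen in place of bromo gives a 7.9-fold higher number from compound 3 to compound 4 (0.90 log units; beyond the scatter) with the chain unchanged, so the number responds to this aromatic carbon as well as to chain length. The bromo, ortho to a methoxy group, goes with the lower number, though this rests on a single pair. Nothing measured here accounts for the step. Going by these compounds, whether chloro, fluoro or a methyl group on this carbon would give a number like that of compound 3 stays open. So does whether the bromo carries the same weight with the shorter chains of compound 1 and compound 2.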